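Chloro for Fluoro on the Distal Ring: an Expectation

The source may report more compounds than this note shows. Statements on the series, on what has been measured and on what is new or still open speak of the compounds shown alone.

Compound 2 `CC(Oc1ccc(Oc2ccc(F)cc2)cc1)C(=O)Cn1nnc(-c2ccc(Cl)cc2)n1` gives 42 nM in an assay on microsomes from brain for inhibition of Fatty-acid amide hydrolase 1 (Rattus norvegicus), read by fluorescence and HPLC, with a stated time of 60 min; on this read-out higher numbers stand for weaker inhibition and lower numbers for stronger inhibition. Compound 1 `CCCCCCCCc1ccc(OC(C)C(=O)Cn2nnc(-c3ccc(Cl)cc3)n2)cc1` gives 35 nM in this assay. For the measured compounds named here, compound 2 stands at the top of these two numbers, with compound 1 its only neighbour, yet the step of a 1.2-fold higher number from compound 1 to compound 2 (0.08 log units; within the scatter) lies within the scatter, so the two cannot be told apart. Compound 3 `CC(Oc1ccc(Oc2ccc(Cl)cc2)cc1)C(=O)Cn1nnc(-c2ccc(Cl)cc2)n1` differs from compound 2 by chloro in place of fluoro on an aromatic carbon. Going by the values given here, no measured step exchanges these two halogens; the one step available, a far larger exchange of octyl for 4-fluorophenoxy, moved the number only within the scatter. The step of a 1.1-fold lower number from compound 2 to compound 3 (0.04 log units; within the scatter) is therefore expected to remain within the scatter. Compound 3 is estimated at 38 nM, between 15 nM and 95 nM.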

Compound 3, half-maximal inhibitory concentration: 76 nM
Beside the measured number, compound 3's estimate is 2.0-fold (0.30 log units) below it; low and high end bracket the measured number.
By their numbers in this assay, from the lowest: compounds 1, 2 and 3 (each within the scatter of the next, the first and the last beyond it).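

Chloro in place of fluoro on this aromatic carbon, para to a large group, gives a 1.8-fold higher number from compound 2 to compound 3 (0.26 log units; within the scatter) and so cannot be told apart from repeat measurement. Set against the octyl compound, 4-chlorophenoxy gives a 2.2-fold higher number from compound 1 to compound 3 (0.34 log units; beyond the scatter) as the only step shown that passes the scatter, and it does so modestly. Nothing available explains this result. From the compounds shown here alone, whether bromo, methoxy or an amine at this position would stay within the scatter remains open. So does whether a chain longer than octyl would shift the number.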